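Flipping One Ring Stereocentre: Expected Solubility of Compound 4

A few compounds are considered here, and "the series" means these few. Any claim that something is new, unique, unknown or untested is made for them only; others in the source may bear on it.

Measured compounds and their values:
compound 1 `CC(C)[C@H](C[C@H]1OC(=O)NC1=O)c1ccc(-c2ccc3cccc(F)c3c2)[nH]c1=O` — 24400 nM
compound 2 `C/C(=C1/OC(=O)NC1=O)C(c1ccc(-c2ccc3cccc(F)c3c2)[nH]c1=O)C(C)C` — 12700 nM
compound 3 `O=C1NC(=O)/C(=C/C(c2ccc(-c3ccc4cccc(F)c4c3)[nH]c2=O)C2CC2)O1` — 3850 nM

In a physicochemical assay for solubility, measured as kinetic solubility, at pH 2 (a lower number here means a less soluble compound, a higher number a more soluble compound), compound 1 gives 24400 nM, the highest of the three numbers. Compound 2 gives 12700 nM, which lies within the usual scatter of the value for compound 1, so the two cannot be placed in order. Compound 3 gives 3850 nM, a lower number that lies beyond the scatter relative to compound 1.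

The new compound, compound 4 `CC(C)[C@H](C[C@@H]1OC(=O)NC1=O)c1ccc(-c2ccc3cccc(F)c3c2)[nH]c1=O`, differs from compound 1 in this way: the two compounds have the same atoms and bonds and differ only in configuration as drawn: 1 of 2 stereo elements differ; a stereocentre at a saturated ring carbon is drawn R in compound 1 and S in compound 4. For the measured compounds named here, no pair of measured compounds that differ in only one place is available, so there is no measured step to lean on for such a change. Because compound 1 gives 24400 nM, the same atoms and bonds in a different arrangement at one ring carbon are expected to give a similar number. Compound 4 is therefore estimated to give 20000 nM, with a range from 8000 nM to 55000 nM. The expected step of a 1.2-fold lower number from compound 1 to compound 4 (0.09 log units; within the scatter) would stay within the scatter, in no clear direction.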

Compound 4, solubility: 25100 nM
Compound 4: middle estimate off by 1.3-fold (0.10 log units), on the low side, and the stated range covers the measured number.
By their numbers in this assay, from the lowest: compound 3; then compounds 2, 1 and 4 (each within the scatter of the next).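

In this assay, inverting the stereocentre at the saturated ring carbon gives a 1.0-fold higher number from compound 1 to compound 4 (0.01 log units; within the scatter) and so leaves no difference that this measurement can resolve. The earlier compounds shown here could not show this, as no two of them differed in only one place. For the compounds shown here, this pair gives the first direct reading at this position, and the comparison is a clean one: the fact that compounds 1 and 4 differ only in the configuration as drawn.

On these data alone, the second stereo element is drawn the same in compound 1 and compound 4, so what its inversion would do remains open. Also open, as far as these compounds go, is whether the ring carbon's configuration would matter as little in a compound carrying an added amine or a carboxylic acid on the shared core.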